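Quinoline carboxamide series: alkoxy to trifluoromethyl at the ring

A few compounds are considered here, and "the series" means these few. Any claim that something is new, unique, unknown or untested is made for them only; others in the source may bear on it.

Measured so far:
compound 1 `CCOc1ccc2nc(C(=O)Nc3c(F)cc(-c4cccc(F)c4)cc3F)c(C)c(C(=O)O)c2c1`, 38.7%
compound 2 `COc1ccc2nc(C(=O)Nc3c(F)cc(-c4cccc(F)c4)cc3F)c(C)c(C(=O)O)c2c1`, 7.24%

In a functional assay on Hep 3B2 cells (Homo sapiens) for antiproliferative activity, read by MTT assay, with a stated time of 24 h, tested at 33.33 ug/mL (on this read-out higher numbers stand for a stronger effect at the one concentration tested and lower numbers for a weaker effect), compound 2 gives 7.24%, the lower of the two numbers; compound 1 gives 38.7%, and the change a number 31.5 percentage points lower from compound 1 to compound 2 (beyond the scatter) lies beyond the scatter. Compound 3 `Cc1c(C(=O)Nc2c(F)cc(-c3cccc(F)c3)cc2F)nc2ccc(C(F)(F)F)cc2c1C(=O)O` differs from compound 2 by trifluoromethyl in place of methoxy on an aromatic carbon. For the measured compounds named here, no measured step involves a trifluoromethyl group, so the one known step gives no direct guide; the only indication is that this position tolerates large swings. Compound 3 is therefore expected with wide uncertainty, a number 12.8 percentage points higher from compound 2 to compound 3 (beyond the scatter), estimated at 20% with a range of 0% to 50%.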

Compound 3, a percentage reported as inhibition, at one concentration (the size of the read-out at that concentration, not a potency): 43.3%
For compound 3 the middle estimate is 23.3 percentage points below the measured one; low and high end bracket the measured number.
By their numbers in this assay, from the lowest: compound 2; then compounds 1 and 3 (each within the scatter of the next).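

In this assay the change to trifluoromethyl gives a number 36.1 percentage points higher from compound 2 to compound 3 (beyond the scatter) and, against the ethoxy compound, a number 4.6 percentage points higher from compound 1 to compound 3 (within the scatter) on this aromatic carbon. An alkoxy group is thus not required here for the higher read-out, and among the three groups methoxy alone stands apart, with trifluoromethyl and ethoxy not separated.

Still open, going by these compounds, is how an amine, a carboxylic acid or a longer alkoxy chain on this carbon would read. No evidence available here bears on the reason for these differences.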